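Replacing Furan-2-yl with Phenyl on the Shared Core

The source may hold more compounds than are shown below. What is called first, only, known or untested is meant among the compounds shown, and "the series" means these compounds.

Of the compounds shown here, two sharing one core have been measured in a functional assay on MGC-803 cells (Homo sapiens) for cytotoxicity, read by MTT assay, with a stated time of 72 h; on this read-out higher numbers stand for weaker inhibition and lower numbers for stronger inhibition. Compound 1 `O=C1C(=Cc2ccc(F)cc2)C(=O)N(c2ccc(Cl)cc2)N1c1ccc(Cl)cc1` gives 26000 nM, and compound 2 `O=C1C(=Cc2ccco2)C(=O)N(c2ccc(Cl)cc2)N1c1ccc(Cl)cc1` gives 12800 nM, the lower of the two numbers. Compound 3 `O=C1C(=Cc2ccccc2)C(=O)N(c2ccc(Cl)cc2)N1c1ccc(Cl)cc1` carries phenyl in place of furan-2-yl on a double-bonded chain carbon bound to a double-bonded ring carbon. Among the compounds with values here, only one measured step bears on this change: a 2.0-fold lower number from compound 1 to compound 2 (0.31 log units; beyond the scatter), modest but beyond the scatter. That step introduced furan-2-yl in place of 4-fluorophenyl, and compound 3 again has a six-membered aromatic ring of carbon only at that place, so a partial reversal is expected. The expected change is a 1.6-fold higher number from compound 2 to compound 3 (0.22 log units; within the scatter), towards a higher number and no larger than the measured step. For compound 3 the estimated value is 21000 nM, with an expected range from 10000 nM to 42000 nM.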

Compound 3, half-maximal inhibitory concentration: 27200 nM
Beside the measured number, compound 3's estimate is 1.3-fold (0.11 log units) below it; the measured number falls inside the stated range.
By their numbers in this assay, from the lowest: compound 2; then compounds 1 and 3 (each within the scatter of the next).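

In this assay the change to phenyl gives a 2.1-fold higher number from compound 2 to compound 3 (0.33 log units; beyond the scatter), so the lower number of compound 2 now stands against two compounds that carry a six-membered aromatic ring of carbon only at this place, not just one. Hydrogen in place of fluoro on an aromatic carbon gives a 1.0-fold higher number from compound 1 to compound 3 (0.02 log units; within the scatter), so the earlier step from 4-fluorophenyl to furan-2-yl can now be read as following the change of ring, with the fluoro group making no difference beyond the scatter. Nothing measured here gives a reason for the difference between the two rings.

Going by these compounds, whether the lower number belongs to furan-2-yl alone, or would also appear with thiophen-2-yl or a pyridine ring, stays open. So does the effect of a hydroxy group or an amine on the phenyl ring.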